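Hydantoin-type side groups on the fluoronaphthyl pyridinone series

The compounds below may be only part of what the source reports. "The series", "measured", "known", "first", "only" and "open" are said of these compounds alone.

Measured so far:
compound 1 `CC(C)C(c1ccc(-c2ccc3cccc(F)c3c2)[nH]c1=O)C1SC(=O)NC1=O`: 25 nM
compound 2 `CC(C)C(/C=C1\NC(=O)NC1=O)c1ccc(-c2ccc3cccc(F)c3c2)[nH]c1=O`: 43 nM
compound 3 `O=C1NC(=O)/C(=C/C(c2ccc(-c3ccc4cccc(F)c4c3)[nH]c2=O)C2CCCC2)O1`: 9 nM

In an assay on membranes from Chem-1 cells for displacement of a labelled ligand from prostaglandin E2 receptor EP3 subtype (Homo sapiens), read by scintillation counting, with a stated time of 2 h (on this read-out lower numbers stand for stronger inhibition and higher numbers for weaker inhibition), compound 2 gives the highest of the three numbers; its step to compound 1, a 1.7-fold higher number from compound 1 to compound 2 (0.24 log units; within the scatter), lies within the scatter, while compound 3 sits well lower, beyond the scatter. Compound 4 `CC(C)C(CC1C(=O)NC(=O)N1C)c1ccc(-c2ccc3cccc(F)c3c2)[nH]c1=O` differs from compound 2 by a group of 9 heavy atoms (5 carbon, 2 nitrogen, 2 oxygen; one five-membered non-aromatic ring with 2 hetero atoms) in place of a group of 8 heavy atoms (4 carbon, 2 nitrogen, 2 oxygen; one five-membered non-aromatic ring with 2 hetero atoms), on a saturated chain carbon bound to an aromatic carbon and a saturated chain carbon. Among the compounds with values here, no measured step bears directly on this change: the only step with a single-site change, from compound 1 to compound 2, swaps one five-membered ring for another and stays within the scatter. Compound 4 is therefore expected to stay close to compound 2, with a step of a 1.3-fold higher number from compound 2 to compound 4 (0.11 log units; within the scatter) and no change beyond the scatter. The estimate for compound 4 is 55 nM, range 18 nM to 170 nM.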

Compound 4, inhibition constant: 17 nM
Estimate against measurement, compound 4: 3.2-fold (0.51 log units) above; measured number below the stated range.
By their numbers in this assay, from the lowest: compounds 3, 4, 1 and 2 (each within the scatter of the next, the first and the last beyond it).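

In this assay, within the data shown here, the (3-methyl-2,5-dioxoimidazolidin-4-yl)methyl group gives the first change beyond the scatter on this saturated chain carbon: a 2.5-fold lower number from compound 2 to compound 4 (0.40 log units; beyond the scatter). Against the 2,4-dioxo-1,3-thiazolidin-5-yl group, the same entering group gives only a 1.5-fold lower number from compound 1 to compound 4 (0.17 log units; within the scatter), so these two groups cannot be separated. No supporting data bear on the origin of the step from compound 2.

As far as these compounds go, compound 2 and compound 4 differ in both the ring methyl and the double bonds, so the contribution of each stays open. Also open, from the compounds shown here alone, is how a carboxylic acid on this carbon would read out.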